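The compounds below may be only part of what the source reports. "The series", "measured", "known", "first", "only" and "open" are said of these compounds alone.

Working notes on the pyridine-amide series in a functional assay on the whole organism with Rattus norvegicus as the target, at a dose of 3 mg/kg by the oral route; a lower number here means a weaker effect, a higher number a stronger effect of the compound at the dose given.

Of the compounds shown here, two carry numbers so far. Compound 1 `COc1ccc(-c2cc(Cl)cc(C(=O)Nc3nn[nH]n3)n2)cc1OC` gives 30% in this assay. Compound 2 `COc1cc(C(=O)Nc2nn[nH]n2)nc(-c2ccc(Cl)cc2)c1` gives 12% in this assay. On these two numbers compound 2 stands lowest, and its nearest neighbour, compound 1, lies higher by an amount beyond the usual scatter. Among the measured compounds shown here, no pair of measured compounds differs in only one place, so no single-change step is available as a yardstick.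

Compound 3 `COc1cc(C(=O)Nc2nn[nH]n2)nc(-c2ccc(NC(C)=O)cc2)c1` is the next compound for this assay. It differs from compound 2 as follows: acetamido in place of chloro on an aromatic carbon. For the measured compounds named here, nothing measured so far shows the effect of this change. Going by the values given here, with no comparable step to lean on, the expected step is a number 8 percentage points higher from compound 2 to compound 3 (within the scatter) in this assay, a change about the size of the scatter and with no firm direction. Compound 3 is accordingly estimated at 20% in this assay, within a wide range of 2% to 45%.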

Compound 3, a percentage reported as inhibition, in the whole organism at one dose (the size of the read-out at that dose, not a potency): 27%
Compound 3: the middle estimate sits 7 percentage points below what was measured, and the stated range covers the measured number.
By their numbers in this assay, from the lowest: compound 2; then compounds 3 and 1 (each within the scatter of the next).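

In this assay, the position para to a large group on the six-membered aromatic ring of carbon only now has its first single-change reading: acetamido in place of chloro goes with a number 15 percentage points higher from compound 2 to compound 3 (beyond the scatter) at the dose given. The position therefore accepts the larger acetamido, with its hydrogen-bond donor and acceptor, with no loss of effect, and this one step points upward. No measurement available bears on the reason for this rise.

Open, going by these compounds, is whether the rise needs the whole acetamido group, which an amine, a carboxylic acid or an amide with a longer chain at the same position would help to settle. Also open, on these data alone, is whether the same change would give a similar step on the core of compound 1.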